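Ring swaps and clearance in a small series

This account rests on a few compounds, and the source may have more. Where it says the series, first, only, none or still open, it means among the compounds named here.

Values in an ADME assay (liver) for metabolic stability, with Liver microsome (Rattus norvegicus) as the target, using microsomes and NADPH, with a stated time of 30 min, tested at 1 uM (a lower number here means slower removal, a higher number faster removal of the compound), for the measured compounds stand below.
Compound 1 `CC(C)(O)C#Cc1cc(C(O)(C(F)(F)F)C(F)(F)F)cnc1N1CCN(S(=O)(=O)c2ccc(N)nc2)CC1` gives 16 mL.min-1.g-1
Compound 2 `CC(C)n1cc(-c2cc(C(O)(C(F)(F)F)C(F)(F)F)cnc2N2CCN(S(=O)(=O)c3ccc(N)nc3)CC2)cn1` gives 198 mL.min-1.g-1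
Compound 3 `CS(=O)(=O)Nc1cccc(-c2cc(C(O)(C(F)(F)F)C(F)(F)F)cnc2N2CCN(S(=O)(=O)c3ccc(N)nc3)CC2)c1` gives 81 mL.min-1.g-1

Compound 3 holds the middle of these three numbers, below compound 2 and above compound 1. Compound 4 `Nc1ccc(S(=O)(=O)N2CCN(c3ncc(C(O)(C(F)(F)F)C(F)(F)F)cc3-c3ccncc3)CC2)cn1` has pyridin-4-yl in place of 3-(methanesulfonamido)phenyl on an aromatic carbon. Three measured steps at that carbon bear on this change: a 12-fold higher number from compound 1 to compound 2 (1.09 log units; beyond the scatter) and a 5.1-fold higher number from compound 1 to compound 3 (0.70 log units; beyond the scatter) are the wider, while a 2.4-fold lower number from compound 2 to compound 3 (0.39 log units; beyond the scatter) is modest. For the measured compounds named here, no measured step covers pyridin-4-yl itself. Compound 4 keeps a six-membered aromatic ring there, so the expectation starts from compound 3 at 81 mL.min-1.g-1 and stays close to it. Only a small move is expected, a 1.4-fold lower number from compound 3 to compound 4 (0.13 log units; within the scatter) in all, not beyond the scatter. Compound 4 is estimated at 60 mL.min-1.g-1 with a range from 22 mL.min-1.g-1 to 165 mL.min-1.g-1 as the expected spread.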

Compound 4, intrinsic clearance in microsomes: 31 mL.min-1.g-1
The estimate for compound 4 lay 1.9-fold (0.29 log units) above the measured number; measured number inside the range.
By their numbers in this assay, from the lowest: compounds 1 and 4 (each within the scatter of the next); then compound 3; then compound 2.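

In this assay, pyridin-4-yl at this aromatic carbon brought a 2.6-fold lower number from compound 3 to compound 4 (0.42 log units; beyond the scatter) and a 6.4-fold lower number from compound 2 to compound 4 (0.81 log units; beyond the scatter), so carrying a six-membered aromatic ring here does not by itself set the number. Against the alkyne, the step is a 1.9-fold higher number from compound 1 to compound 4 (0.29 log units; within the scatter), which shows that a ring at this carbon can sit level with 3-hydroxy-3-methylbut-1-yn-1-yl. Nothing measured here accounts for these differences. On these data alone, whether the ring nitrogen or the loss of the methanesulfonamido group matters stays open; a plain phenyl group at this carbon would separate the two.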